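Fluoro on the formyl compound: a series at its limit

The source may report more compounds than this note shows. Statements on the series, on what has been measured and on what is new or still open speak of the compounds shown alone.

Measured in a functional assay on MCF7 cells (Homo sapiens) for antiproliferative activity, read by WST assay, with a stated time of 3 days; on this read-out lower numbers stand for stronger inhibition and higher numbers for weaker inhibition:
- compound 1 `CNc1cc(=O)[nH]c(=O)n1[C@@H]1O[C@H](CO)[C@@H](O)[C@H]1O`: > 50000 nM
- compound 2 `O=c1cc(NO)n([C@@H]2O[C@H](CO)[C@@H](O)[C@H]2O)c(=O)[nH]1`: > 50000 nM
- compound 3 `O=Cc1cc(=O)[nH]c(=O)n1[C@@H]1O[C@H](CO)[C@@H](O)[C@H]1O`: > 50000 nM

Compound 3 stands at > 50000 nM, which is a limit and not a number. The series as a whole shows (the limit of > 50000 nM in this assay, at which 3 of the 3 values shown sit). Compound 4 `O=Cc1c(F)c(=O)[nH]c(=O)n1[C@@H]1O[C@H](CO)[C@@H](O)[C@H]1O` carries fluoro in place of hydrogen on an aromatic carbon, ortho to a formyl group: fluoro in place of hydrogen on an aromatic carbon. Among the measured compounds shown here, two measured steps end in compound 3, a step that the two limits leave unreadable from compound 1 to compound 3 and a step that the two limits leave unreadable from compound 2 to compound 3, and no measured step replaces this hydrogen. Neither gives a size or direction, so only a weak expectation is possible in this assay, that activity stays near the limit. The expected step is an at least 1.6-fold lower number from compound 3 to compound 4 (0.22 log units; that floor lies within the scatter). Compound 4 is estimated at 30000 nM, with an expected range of 3000 nM to 60000 nM.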

Compound 4, half-maximal inhibitory concentration: 23700 nM
Beside the measured number, compound 4's estimate is 1.3-fold (0.10 log units) above it; the measured number falls inside the stated range.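

In this assay, among the compounds shown here, fluoro on the aromatic carbon ortho to a formyl group gives an at least 2.1-fold lower number from compound 3 to compound 4 (0.32 log units; beyond the scatter) and is the first change here to bring a value off the limit. The other compounds stay at that limit: (the limit of > 50000 nM in this assay, at which 3 of the 4 values shown sit). For the compounds shown here, compound 3 gives > 50000 nM as a limit and not a number, so this step is a floor only, and the earlier steps among compound 1, compound 2 and compound 3 cannot be read.

From the compounds shown here alone, whether chloro or methyl on this carbon would also leave the limit remains open. Also open, going by these compounds, is whether fluoro has the same result with methylamino or hydroxyamino in place of formyl.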